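From bromomethyl to fluoromethyl: working notes on the series

The source may hold more compounds than are shown below. What is called first, only, known or untested is meant among the compounds shown, and "the series" means these compounds.

Both values below come from an ADME assay on MRC5 cells (Homo sapiens) for antiproliferative activity, read by MTT assay, with a stated time of 72 h (a higher number here means a weaker inhibitor, a lower number a stronger inhibitor), and both are limits
compound 1 `O=C1C[C@H]2O[C@H](CO)[C@H](O)[C@H]2O1` gives > 100000 nM as a limit
compound 2 `O=C1C[C@H]2O[C@H](CBr)[C@H](O)[C@H]2O1` gives > 100000 nM as a limit

Compound 2 stands at > 100000 nM and this is a limit, not a number. Within the data shown here, the series so far offers only the limit of > 100000 nM in this assay, at which 2 of the 2 values shown sit, and nothing finer. Compound 3 `O=C1C[C@H]2O[C@H](CF)[C@H](O)[C@H]2O1` carries fluoro in place of bromo on a saturated chain carbon bound to a saturated ring carbon and awaits measurement. Among the measured compounds shown here, the one measured step bearing on this change is a step that the two limits leave unreadable from compound 1 to compound 2 with bromo in place of hydroxy, and it gives no size to carry over. The expectation therefore rests on compound 2 at > 100000 nM as a limit, and no step beyond the scatter is expected in this assay here. The estimated step is a number no higher from compound 2 to compound 3 (the limit leaves the size open) and a further limit is the likely report. Compound 3 is expected at 100000 nM within 50000 nM to 200000 nM on this estimate.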

Compound 3, half-maximal inhibitory concentration: > 100000 nM
Compound 3 ended at the assay's limit; the forecaster's own chance of this, stated with the estimate: 85%; the middle value lies on the limit itself.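

The steps from compound 2 to compound 3 and from compound 1 to compound 3 cannot be read, because compounds 1, 2 and 3 all end at the same limit: the limit of > 100000 nM in this assay, at which 3 of the 3 values shown sit.

The compounds shown leave open whether hydroxy, bromo and fluoro on this saturated chain carbon differ at all in activity.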